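Replacing cyclopentyl with 3,3-difluorocyclobutyl

The compounds below may be only part of what the source reports. "The series", "measured", "known", "first", "only" and "open" are said of these compounds alone.

Values measured in a physicochemical assay for solubility, using the shake flask method, in simulated intestinal fluid, measured as kinetic solubility, with a stated time of 20 h, at pH 6.5; a lower number here means a less soluble compound, a higher number a more soluble compound:
- Compound 1 `Fc1ccc(-c2nc3cnc(Nc4ccccn4)cc3[nH]2)cc1C(F)(F)F`: >= 50000 nM, a limit
- Compound 2 `FC(F)(F)c1cccc(-c2nc3cnc(Nc4ccc(-c5nnn[nH]5)cn4)cc3[nH]2)c1`: < 5000 nM, a limit
- Compound 3 `FC(F)(F)c1ccc(Nc2cc3[nH]c(C4CCCC4)nc3cn2)nc1`: 85000 nM

Among these three, only compound 3 has an actual number, 85000 nM, so it is the natural starting point. The values for the other two compounds are limits of the assay, not numbers.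

In compound 4 `FC1(F)CC(c2nc3cnc(Nc4ccc(C(F)(F)F)cn4)cc3[nH]2)C1`, 3,3-difluorocyclobutyl takes the place of cyclopentyl on an aromatic carbon: 3,3-difluorocyclobutyl in place of cyclopentyl on an aromatic carbon. Within the data shown here, no measured pair of compounds shows this change, so any forecast in this assay is uncertain. The estimated 1.3-fold lower number from compound 3 to compound 4 (0.12 log units; within the scatter) is expected to stay within the usual scatter. For compound 4 the expected value is 65000 nM, with an estimated range from 22000 nM to 150000 nM.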

Compound 4, solubility: 161000 nM
Compound 4: middle estimate off by 2.5-fold (0.39 log units), on the low side; the whole stated range lies below it.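

Among these compounds, compound 3 and compound 4 form the first pair here that differs in only one place, on an aromatic carbon between two ring nitrogen atoms. In this assay, exchanging cyclopentyl for 3,3-difluorocyclobutyl gives a 1.9-fold higher number from compound 3 to compound 4 (0.28 log units; within the scatter) and so the two values cannot be told apart. Nothing measured here gives a cause for this step.

As far as these compounds go, it remains open how this assay would respond to an amine, a carboxylic acid or a longer chain on this carbon. A single pair also cannot show whether the same exchange would behave alike with a different group on the rest of the molecule.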